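The source may report more compounds than this note shows. Statements on the series, on what has been measured and on what is new or still open speak of the compounds shown alone.

Compound 2 `c1ccc(OC[C@@H]2CCN2)cc1` holds the higher of the two numbers recorded so far: in an assay on cell membranes for displacement of a labelled ligand from Neuronal acetylcholine receptor; alpha4/beta2 (Rattus norvegicus), read by scintillation counting (a higher number here means a weaker inhibitor, a lower number a stronger inhibitor), compound 2 gives 52 nM. Its nearest neighbour, compound 1 `CN1CC[C@H]1COc1cccc(O)c1`, gives 8.5 nM in this assay, a lower number that lies beyond the scatter. Compound 3 `CN1CC[C@H]1COc1ccccc1` has not yet been measured. It differs from compound 2 in one place: methyl in place of hydrogen on an amine nitrogen in a ring. Among the measured compounds shown here, no measured pair isolates this change, so the size of the step is an open question; the step of a 1.2-fold higher number from compound 2 to compound 3 (0.06 log units; within the scatter) is expected to stay within the scatter, in either direction. For compound 3 the expected value is 60 nM, with a range from 15 nM to 250 nM.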

Compound 3, inhibition constant: 101 nM
Beside the measured number, compound 3's estimate is 1.7-fold (0.23 log units) below it; measured number inside the range.
By their numbers in this assay, from the lowest: compound 1; then compounds 2 and 3 (each within the scatter of the next).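

In this assay, methyl in place of hydrogen on the amine nitrogen in the ring gives a 1.9-fold higher number from compound 2 to compound 3 (0.29 log units; within the scatter), so at this position the change cannot be told from the scatter. The hydroxy matters far more: hydrogen in place of hydroxy on an aromatic carbon gives a 12-fold higher number from compound 1 to compound 3 (1.07 log units; beyond the scatter). Nothing at hand gives a reason for either step. From the compounds shown here alone, whether an ethyl or benzyl group on that nitrogen would also stay within the scatter of compound 2 remains open. So does whether a methoxy or an amine could stand in for the hydroxy.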